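The source may report more compounds than this note shows. Statements on the series, on what has been measured and on what is new or still open speak of the compounds shown alone.

Measured in an ADME assay on L02 cells (Homo sapiens) for antiproliferative activity, read by CCK-8 assay, with a stated time of 6 days; a lower number here means a stronger inhibitor, a higher number a weaker inhibitor
compound 1 `CCN(c1ccc(C#N)c(Cl)c1)c1cc(-c2ccncc2)ccc1C` gives 1730 nM
compound 2 `CCN(c1ccc(C#N)c(Cl)c1)c1cc(-n2cnc3ccccc32)ccc1C` gives "not determined" (no result reported)
compound 3 `CCN(c1ccc(C#N)c(Cl)c1)c1cc(-n2cccn2)ccc1C` gives "not determined" (no result reported)

Compound 3 has no single number in this assay and so holds no place on the scale. Compound 2 is the one further entry in the same position, which leaves compound 1 as the only numerical reference in the series. Going by the values given here, no step between measured compounds is available, and the effect of changing the group at this position has not been measured.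

The next compound is compound 4 `CCN(c1ccc(C#N)c(Cl)c1)c1cc(-c2cccnc2)ccc1C`, still to be measured. The change is pyridin-3-yl in place of 1H-pyrazol-1-yl on an aromatic carbon and consists of pyridin-3-yl in place of 1H-pyrazol-1-yl on an aromatic carbon. The rest of the structure stays the same.

With no number for compound 3, the size of this step cannot be read from the data. The expectation therefore rests on compound 1 at 1730 nM as the single anchor. No shift beyond the usual scatter from that value is expected in either direction, although a single reference leaves this expectation loose.

The estimated value for compound 4 is 1900 nM with an expected range from 550 nM to 6500 nM in this assay as the read-out.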

Compound 4, half-maximal inhibitory concentration: 12700 nM
Beside the measured number, compound 4's estimate is 6.7-fold (0.83 log units) below it; the measured number lies above the stated range.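

In this assay, the series now has its first readable step, a 7.3-fold higher number from compound 1 to compound 4 (0.87 log units; beyond the scatter), with pyridin-3-yl in place of pyridin-4-yl on the same aromatic carbon and the rest of the structure unchanged. This position therefore distinguishes between these two pyridine isomers, with the number moving beyond the usual scatter towards weaker inhibition, although this rests on a single pair; steps involving compound 2 or compound 3 cannot be read, as neither has a single number. Nothing available bears on the reason for this shift.

Going by these compounds, it remains open whether the difference between compound 1 and compound 4 extends to other groups on this carbon, such as pyridin-2-yl, an unsubstituted phenyl ring, a morpholine or a carboxylic acid, since the two values shown cannot establish a trend across ring types. On these data alone, the places of the 1H-pyrazol-1-yl group of compound 3 and the fused ring group of compound 2 on this scale also remain unknown, so the effect of attaching a ring through nitrogen at this position is still undefined.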